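This account rests on a few compounds, and the source may have more. Where it says the series, first, only, none or still open, it means among the compounds named here.

Two compounds built on a shared core differ only in the chain attached to the core. Compound 1 `CCCCCCOc1ccc(-n2cnnc2CC)cc1` gives 13.2 mg/kg in a functional assay on the whole organism (strain C57B/6) with Mus musculus as the target, in the maximal electroshock model; on this read-out lower numbers stand for an effect already at smaller amounts and higher numbers for an effect only at larger amounts of compound. Compound 2 `CCCCCCOc1ccc(-n2cnnc2CCCCC)cc1` gives 32.8 mg/kg in this assay; among the two numbers it stands highest, its nearest neighbour being compound 1, and the step of a 2.5-fold higher number from compound 1 to compound 2 (0.40 log units; beyond the scatter) lies beyond the scatter. Compound 3 `CCCCCCCCCc1nncn1-c1ccc(OCCCCCC)cc1` has not yet been measured. It differs from compound 2 by butyl in place of hydrogen on a saturated chain carbon, five bonds along the chain from an aromatic carbon. Among the measured compounds shown here, the single measured step that bears on this change is a 2.5-fold higher number from compound 1 to compound 2 (0.40 log units; beyond the scatter), which concerns the same chain and gave a modest rise. Extending that chain once more is therefore expected to raise the number in this assay again, by a comparable or somewhat larger amount, though a single step gives only a weak footing. For compound 3 the expected step is a 2.0-fold higher number from compound 2 to compound 3 (0.30 log units; within the scatter). Compound 3 is thus estimated to give about 65 mg/kg in this assay, with a range from 30 mg/kg to 140 mg/kg.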

Compound 3, dose for half-maximal effect: > 40 mg/kg
Compound 3 was reported as a limit; the forecaster's own chance of this, stated with the estimate: 15%; the middle value lies beyond the limit too.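

In this assay compound 3 is reported only as a limit, not as a number: the limit of > 40 mg/kg in this assay, at which 1 of the 3 values shown sits. Butyl in place of hydrogen on a saturated chain carbon, five bonds along the chain from an aromatic carbon, gives an at least 1.2-fold higher number from compound 2 to compound 3 (0.08 log units; that floor lies within the scatter), so this limit does not set the longest chain apart from the one before it, and no further rise can be claimed from this change. Taken over the whole chain, heptyl in place of hydrogen gives an at least 3.0-fold higher number from compound 1 to compound 3 (0.48 log units; beyond the scatter), which shows that the longest chain shown stays separated from the shortest by more than the scatter.

Going by these compounds, how far the true number for compound 3 lies past its limit remains open. Also open, on these data alone, is how an amine or a carboxylic acid in place of this chain would read on the same scale.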